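Fluorine Position Swap Across Two Related Cores

The source may report more compounds than this note shows. Statements on the series, on what has been measured and on what is new or still open speak of the compounds shown alone.

Compound 1 `O=C(NNC(=O)c1ccccc1F)c1cccc(NS(=O)(=O)c2cnc(O)nc2O)c1` gives 10800 nM in a functional assay on OVCAR-3 cells (Homo sapiens) for antiproliferative activity, read by MTT assay, with a stated time of 24 h; on this read-out lower numbers stand for stronger inhibition and higher numbers for weaker inhibition. Compound 2 `O=C(NNC(=O)c1cccc(NS(=O)(=O)c2cnc(O)nc2O)c1)c1ccc(F)cc1` reaches only the limit > 20000 nM in this assay, a limit and not a number. The change is 4-fluorophenyl in place of 2-fluorophenyl on a carbonyl carbon and gives an at least 1.8-fold higher number from compound 1 to compound 2 (0.26 log units; that floor lies within the scatter), which sits at the limit (the limit of > 20000 nM in this assay, at which 1 of the 3 values shown sits). Compound 3 `O=C(NNC(=O)c1ccccc1NS(=O)(=O)c1cnc(O)nc1O)c1ccccc1F` gives 15300 nM in this assay; it is the highest of the two numbers, and its gap to compound 1 lies within the scatter. The difference between the cores of compound 1 and compound 3 is not broken down here. Compound 4 `O=C(NNC(=O)c1ccccc1NS(=O)(=O)c1cnc(O)nc1O)c1ccc(F)cc1` carries the same change as compound 2, namely (4-fluorophenyl in place of 2-fluorophenyl on a carbonyl carbon), at the same place. Going by the values given here, a step like the one from compound 1 to compound 2 is expected, so the step of a 1.8-fold higher number from compound 3 to compound 4 (0.26 log units; within the scatter) is an estimate that rests on an at least 1.8-fold higher number from compound 1 to compound 2 (0.26 log units; that floor lies within the scatter). Compound 4 is expected to give about 28000 nM in this assay, between 14000 nM and 60000 nM, likely reported only as a limit.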

Compound 4, half-maximal inhibitory concentration: 15100 nM
The estimate for compound 4 lay 1.9-fold (0.27 log units) above the measured number, and the stated range covers the measured number.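

On the core of compound 3, 4-fluorophenyl in place of 2-fluorophenyl on a carbonyl carbon gives a 1.0-fold lower number from compound 3 to compound 4 (0.01 log units; within the scatter) in this assay, so on this core the change leaves the number within the scatter. Compound 2 gives > 20000 nM, a limit and not a number. Whether the change carries over from one core to the other in the same way is neither confirmed nor ruled out: the same change on two cores in this assay, an at least 1.8-fold higher number (0.26 log units; that floor lies within the scatter) from compound 1 to compound 2 and a 1.0-fold lower number (0.01 log units; within the scatter) from compound 3 to compound 4; the limit leaves it open whether they differ

The compounds shown vary this carbonyl substituent only between 2-fluorophenyl and 4-fluorophenyl, and all values come from this assay. Still open, going by these compounds, is whether a phenyl ring carrying an amine or a carboxylic acid in place of the fluorine would give a clearly different number on either core.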